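The source may report more compounds than this note shows. Statements on the series, on what has been measured and on what is new or still open speak of the compounds shown alone.

Within the data shown here, compound 1 `C=CC[C@H]1C[C@]2([C@@H](C)Cc3ccc(OC)nc3)OCOC2=CC1=O` is the first reference. In a functional assay on NCI-H460 cells (Homo sapiens) for antiproliferative activity, with a stated time of 72 h (on this read-out higher numbers stand for weaker inhibition and lower numbers for stronger inhibition), compound 1 gives 330 nM. Compound 2 `C=CC[C@H]1C[C@]2([C@@H](C)Cc3cnc(OC)cc3F)OCOC2=CC1=O` carries fluoro in place of hydrogen on an aromatic carbon. For compound 2 the read-out is only a limit of the assay, > 20000 nM. The step is an at least 60-fold higher number from compound 1 to compound 2 (1.78 log units; beyond the scatter), as far as the limit of > 20000 nM in this assay, at which 1 of the 3 values shown sits, lets it be seen. Compound 3 `C=CC[C@H]1C[C@]2([C@@H](C)Cc3ccc(OC)cc3F)OCOC2=CC1=O` has a different core; the difference between the two cores is not broken down here. In this assay compound 3 gives 94 nM, a lower number than compound 1. Compound 4 `C=CC[C@H]1C[C@]2([C@@H](C)Cc3cc(F)c(OC)cc3F)OCOC2=CC1=O` differs from compound 3 by fluoro in place of hydrogen on an aromatic carbon. This is the same kind of change as from compound 1 to compound 2, but the place differs: now on a ring of carbon only, ortho to a methoxy group, meta to a large group and para to a fluoro group, rather than ortho to a large group, meta to a methoxy group and opposite the ring nitrogen. Because the step of an at least 60-fold higher number from compound 1 to compound 2 (1.78 log units; beyond the scatter) was made at a different place, only a smaller loss is expected here, a 2.7-fold higher number from compound 3 to compound 4 (0.42 log units; beyond the scatter). Compound 4 is estimated at 250 nM, between 60 nM and 2000 nM.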

Compound 4, half-maximal inhibitory concentration: 59 nM
The estimate for compound 4 lay 4.2-fold (0.63 log units) above the measured number; the measured number lies below the stated range.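

The same change does not carry over from one core to the other in this assay: the same change on two cores in this assay, an at least 60-fold higher number (1.78 log units; beyond the scatter) from compound 1 to compound 2 and a 1.6-fold lower number (0.20 log units; within the scatter) from compound 3 to compound 4, at least 96-fold (1.98 log units) apart, beyond the scatter of two such steps. Compound 2 stands at a limit of the assay, not at a number: the limit of > 20000 nM in this assay, at which 1 of the 4 values shown sits. On the ring of carbon only, the step is a 1.6-fold lower number from compound 3 to compound 4 (0.20 log units; within the scatter), which cannot be told from scatter, and the fluoro group sits at a different place on each core, leaving it unresolved whether the core or the place decides the outcome.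

Still open, as far as these compounds go, is how a fluoro group would fare on the core of compound 1 at the place it holds in compound 4. Also open, from the compounds shown here alone, is whether a chloro or methyl group at these places would give the same result as fluoro.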